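A few compounds are considered here, and "the series" means these few. Any claim that something is new, unique, unknown or untested is made for them only; others in the source may bear on it.

Measured in an ADME assay on microsomes from liver (Homo sapiens) for metabolic stability; a lower number here means that the compound disappears faster, a higher number that the compound lasts longer:
Compound 1 `CC(C)C(c1ccc(-c2ccc3cccc(F)c3c2)[nH]c1=O)N1CCCCS1(=O)=O` gives 0.373 h
Compound 2 `CC(C)C(Cc1ncc[nH]1)c1ccc(-c2ccc3cccc(F)c3c2)[nH]c1=O` gives 0.106 h
Compound 3 `CC(C)C(Cc1nnn[nH]1)c1ccc(-c2ccc3cccc(F)c3c2)[nH]c1=O` gives > 3 h as a limit of the assay, not a number

For compound 3 only a limit is known (the limit of > 3 h in this assay, at which 1 of the 3 values shown sits). Compound 4 `CC(C)C(CC(N)=O)c1ccc(-c2ccc3cccc(F)c3c2)[nH]c1=O` carries carbamoyl in place of 1H-tetrazol-5-yl on a saturated chain carbon, two bonds along the chain from an aromatic carbon. Among the compounds with values here, two measured steps bear on this change, one large (an at least 28-fold higher number from compound 2 to compound 3 (1.45 log units; beyond the scatter)) and one at least modest (an at least 8.0-fold higher number from compound 1 to compound 3 (0.90 log units; beyond the scatter)). Both show that the group at this place can shift the half-life strongly, yet neither involves carbamoyl. In this assay a modest drop is therefore expected (an at least 3.0-fold lower number from compound 3 to compound 4 (0.47 log units; beyond the scatter)). The estimated half-life for compound 4 is 1 h (expected range 0.3 h to 3 h).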

Compound 4, half-life: < 0.0667 h
Compound 4: a limit, no number (the forecaster's own chance of this, stated with the estimate: 15%); middle value at least 14-fold (1.17 log units) from the limit.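

In this assay compound 4 gives < 0.0667 h as a limit of the assay, not a number. Carbamoyl does not keep the long half-life of 1H-tetrazol-5-yl at this place (step: an at least 44-fold lower number from compound 3 to compound 4 (1.65 log units; beyond the scatter)), and the change from the group in compound 1 also lies beyond the scatter (step: an at least 5.5-fold lower number from compound 1 to compound 4 (0.74 log units; beyond the scatter)). Carbamoyl and 1H-imidazol-2-yl cannot be ordered, as the floor of their step lies within the scatter (step: an at least 1.5-fold lower number from compound 2 to compound 4 (0.20 log units; that floor lies within the scatter)). The compounds shown leave open whether a carboxylic acid at this place would behave like 1H-tetrazol-5-yl or like carbamoyl.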